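Replacing a Branched Chain with a Halogenated Ring

The source may hold more compounds than are shown below. What is called first, only, known or untested is meant among the compounds shown, and "the series" means these compounds.

Compound 1, `CC(C)Cc1ccc2c(NCCCNCc3ccco3)ccnc2c1`, gives 16000 nM in an ADME assay on HepG2 cells (Homo sapiens) for cytotoxicity, read by luminescence, CellTiter-Glo and ATP content, with a stated time of 72 h; on this read-out lower numbers stand for an effect already at smaller amounts and higher numbers for an effect only at larger amounts of compound.
Compound 2, `CCC(CC)c1ccc2c(NCCCNCc3cc(F)ccc3OC)ccnc2c1`, gives 7860 nM in this assay.
Compound 3, `COc1ccc(F)cc1CNCCCNc1ccnc2cc(-c3ccc(F)cc3)ccc12`, gives 770 nM in this assay.

Among these three numbers compound 1 stands highest: compound 2 is nearest, and compound 3 furthest from it. Going by the values given here, the one measured step that changes a single place, a 10-fold lower number from compound 2 to compound 3 (1.01 log units; beyond the scatter), swaps a branched saturated chain for an aromatic ring carrying a fluorine, and the number falls sharply.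

Compound 4, `Fc1ccc(Cc2ccc3c(NCCCNCc4ccco4)ccnc3c2)c(Cl)c1`, is not yet measured. It is derived from compound 1 by a change of the same kind: 2-chloro-4-fluorophenyl in place of isopropyl on a saturated chain carbon bound to an aromatic carbon. The isobutyl group of compound 1 becomes a 2-chloro-4-fluorobenzyl group, so again a small saturated branch gives way to a halogenated aromatic ring. Among the compounds with values here, the step from compound 2 to compound 3 is the only guide here, and it points toward a large drop. Because a 10-fold lower number from compound 2 to compound 3 (1.01 log units; beyond the scatter) was beyond the scatter, a lower number for compound 4 than for compound 1 is expected, on the order of a 6.4-fold lower number from compound 1 to compound 4 (0.81 log units; beyond the scatter). The estimate for compound 4 in this assay is therefore 2500 nM, within a range of 800 nM to 8000 nM.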

Compound 4, half-maximal effective concentration: 5730 nM
For compound 4 the middle estimate is 2.3-fold (0.36 log units) below the measured one; the measured number falls inside the stated range.
By their numbers in this assay, from the lowest: compound 3; then compounds 4 and 2 (each within the scatter of the next); then compound 1.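

In this assay, replacing the isobutyl group of compound 1 with 2-chloro-4-fluorobenzyl gives a 2.8-fold lower number from compound 1 to compound 4 (0.45 log units; beyond the scatter) and so lowers the number on a different parent compound and at a different kind of place. The earlier step, a 10-fold lower number from compound 2 to compound 3 (1.01 log units; beyond the scatter), put a halogenated aromatic ring directly on an aromatic carbon, whereas here the ring sits on a saturated chain carbon bound to an aromatic carbon, and the step is modest rather than large. With the two steps pointing the same way, the lower number is no longer tied to a single pair of compounds, although two steps are too few to establish a rule, and nothing available explains why the number moves.

The compounds shown cannot separate the effect of the aromatic ring from that of its halogens, so a plain benzyl group, carrying neither chlorine nor fluorine, would be the informative comparison at this place. On these data alone, it also remains open how the number would respond to an amine or a carboxylic acid on that ring, or to a longer chain joining the ring to the core.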